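Aryl substituent change in a chromone series: compound 4

The source may hold more compounds than are shown below. What is called first, only, known or untested is meant among the compounds shown, and "the series" means these compounds.

Values in a functional assay on KBVIN cells (Homo sapiens) for antiproliferative activity, read by sulforhodamine B assay, with a stated time of 3 days; a higher number here means that more compound is needed for the effect, a lower number that less compound is needed:
compound 1, `CCCCc1ccc(-c2cc(=O)c3c(o2)C(CC)(CC)C(=O)C(CC)=C3O)cc1`: 37 uM
compound 2, `CCC1=C(O)c2c(oc(-c3ccc(C(F)(F)F)cc3)cc2=O)C(CC)(CC)C1=O`: 10.4 uM
compound 3, `CCC1=C(O)c2c(oc(-c3ccc(Br)cc3)cc2=O)C(CC)(CC)C1=O`: 15.7 uM

Compound 3 gives the second highest of the three numbers; its nearest neighbour is compound 2, with a 1.5-fold higher number from compound 2 to compound 3 (0.18 log units; within the scatter), and its furthest is compound 1, with a 2.4-fold lower number from compound 1 to compound 3 (0.37 log units; beyond the scatter). Compound 4, `CCC1=C(O)c2c(oc(-c3ccccc3OC)cc2=O)C(CC)(CC)C1=O`, is not yet measured in this assay. It differs from compound 3 by 2-methoxyphenyl in place of 4-bromophenyl on an aromatic carbon.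

The measured steps all concern changes of the group on the 4-position of the phenyl ring: a 3.6-fold lower number from compound 1 to compound 2 (0.55 log units; beyond the scatter) and a 2.4-fold lower number from compound 1 to compound 3 (0.37 log units; beyond the scatter) are modest, while a 1.5-fold higher number from compound 2 to compound 3 (0.18 log units; within the scatter) is within the scatter. None of them concerns a 2-methoxyphenyl, so they bear only loosely on the step to compound 4. Among the three aryl groups measured, the spread of numbers is narrow, and compound 4 is expected to stay within it: the step of a 1.3-fold higher number from compound 3 to compound 4 (0.11 log units; within the scatter) is expected to fall within the scatter. For compound 4 in this assay the estimate is 20 uM, with a range from 8 uM to 50 uM.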

Compound 4, concentration for half-maximal effect: 3.26 uM
Estimate against measurement, compound 4: 6.1-fold (0.79 log units) above; measured number outside the range, below it.
By their numbers in this assay, from the lowest: compound 4; then compounds 2 and 3 (each within the scatter of the next); then compound 1.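

In this assay, replacing 4-bromophenyl with 2-methoxyphenyl gives a 4.8-fold lower number from compound 3 to compound 4 (0.68 log units; beyond the scatter), a larger drop than the step between the trifluoromethyl and bromo compounds, which lies within the scatter. Compound 4, at 3.26 uM, gives the lowest number of the four and is the only one shown with an oxygen-bearing substituent on the phenyl ring, so the aryl group at this position can move the number further than compounds 1 to 3 indicated. Nothing available explains the gain, and this single step changes both the substituent and its place on the phenyl ring.

No pair shown separates the effect of the methoxy group from the effect of where it sits. Going by these compounds alone, it also remains open whether an ethoxy group or an amine on the phenyl ring would follow compound 4 or the earlier compounds.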